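From compound 3 to compound 4: one group exchanged

This account rests on a few compounds, and the source may have more. Where it says the series, first, only, none or still open, it means among the compounds named here.

Values measured so far in a functional assay on HL-60 cells (Homo sapiens) for inhibition, read by CCK-8 assay, with a stated time of 48 h; on this read-out lower numbers stand for stronger inhibition and higher numbers for weaker inhibition
- compound 1 `COc1ccc(Oc2ccc(C(C)C)cc2-c2ccsc2S(=O)(=O)NCCNC(=S)Nc2ccc([N+](=O)[O-])cc2)cc1OC` gives 11200 nM
- compound 2 `O=C(NCCNS(=O)(=O)c1ccc(-c2ccccc2OCc2cccc(O)c2)s1)Nc1cc(C(F)(F)F)cc(C(F)(F)F)c1` gives 4000 nM
- compound 3 `COc1ccc(NC(=O)NCCNS(=O)(=O)c2sccc2-c2ccc(C)cc2Oc2ccc(O)c(O)c2)cc1` gives 6100 nM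

Compound 3 (6100 nM) lies within the usual scatter of both compound 2 (4000 nM) and compound 1 (11200 nM), so these numbers support no ranking of compound 3 against either neighbour.

Compound 4 `COc1ccc(NC(=S)NCCNS(=O)(=O)c2sccc2-c2ccc(C)cc2Oc2ccc(O)c(O)c2)cc1` has not yet been measured. It keeps the core of compound 3 and differs in one place, on an amine nitrogen whose other neighbours are saturated chain carbon. There the (4-methoxyphenyl)carbamoyl group leaves and a group with no common name enters (a group of 11 heavy atoms (8 carbon, 1 nitrogen, 1 oxygen, 1 sulfur; one six-membered aromatic ring of carbon only) in place of a group of 11 heavy atoms (8 carbon, 1 nitrogen, 2 oxygen; one six-membered aromatic ring of carbon only), on an amine nitrogen). The new group has a sulfur where the old one has a second oxygen.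

Among the measured compounds shown here, no pair of measured compounds shows this exchange alone, so the data offer no direct guide. The expectation in this assay is therefore for no step beyond the scatter, in either direction. The expected move is small (a 1.2-fold lower number from compound 3 to compound 4 (0.09 log units; within the scatter)). For compound 4 the estimate is 5000 nM (range 2000 nM to 12000 nM).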

Compound 4, half-maximal inhibitory concentration: 4100 nM
The estimate for compound 4 lay 1.2-fold (0.09 log units) above the measured number; low and high end bracket the measured number.
By their numbers in this assay, from the lowest: compounds 2, 4, 3 and 1 (each within the scatter of the next, the first and the last beyond it).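

In this assay, replacing the (4-methoxyphenyl)carbamoyl group on the amine nitrogen with the matching group that has a sulfur in place of the second oxygen gives a 1.5-fold lower number from compound 3 to compound 4 (0.17 log units; within the scatter). This is the first pair shown that differs in only one place, and it indicates that this single-atom exchange, at this position and on this core, produces no change that can be told from assay scatter. No supporting measurement bears on the result, so it stays an observation without an explanation.

One exchange gives no picture of how much this position tolerates overall. As far as these compounds go, whether an acetyl group on that amine nitrogen, or a carboxylic acid in place of the methoxy group on the aromatic ring, would move the number beyond the scatter remains open.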